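A few compounds are considered here, and "the series" means these few. Any claim that something is new, unique, unknown or untested is made for them only; others in the source may bear on it.

Of the compounds shown here, three built on one shared core have been tested in a functional assay on A549 cells (Homo sapiens) for antiproliferative activity, read by MTT assay, with a stated time of 48 h; on this read-out lower numbers stand for stronger inhibition and higher numbers for weaker inhibition. Compound 1 `N#CC1=C(N)Oc2c(c3nc4ccccc4nc3c3ccccc23)C12C(=O)N(Cc1cnnn1-c1ccc([N+](=O)[O-])cc1)c1ccccc12` carries a 4-nitrophenyl on an aromatic nitrogen, and in this assay compound 1 reaches only the limit of > 50000 nM. Compound 2 `Cc1ccc(-n2nncc2CN2C(=O)C3(C(C#N)=C(N)Oc4c3c3nc5ccccc5nc3c3ccccc43)c3ccccc32)c(C)c1` carries a 2,4-dimethylphenyl at that place, and compound 2 likewise gives only the limit of > 50000 nM. The step that the two limits leave unreadable from compound 1 to compound 2 therefore cannot be read, both values resting at the limit of > 50000 nM in this assay, at which 2 of the 3 values shown sit. Going by the values given here, compound 3 `N#CC1=C(N)Oc2c(N)cc3nc4ccccc4nc3c2C12C(=O)N(Cc1cnnn1-c1cccc(Br)c1)c1ccccc12` holds the only actual number, 18900 nM in this assay. The other two values are limits.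

Compound 4 `CCc1cccc(CC)c1-n1nncc1CN1C(=O)C2(C(C#N)=C(N)Oc3c(N)cc4nc5ccccc5nc4c32)c2ccccc21` is compound 3 with one change: 2,6-diethylphenyl in place of 3-bromophenyl on an aromatic nitrogen. Among the compounds with values here, the single measured step that swaps the group on this aromatic nitrogen, from compound 1 to compound 2, is unreadable and so gives no guide to size or direction. With no readable step to lean on, the expected change from compound 3 to compound 4 is a 1.3-fold higher number from compound 3 to compound 4 (0.12 log units; within the scatter), nothing beyond the scatter. Compound 4 is thus estimated at 25000 nM, within a range of 8000 nM to 80000 nM.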

Compound 4, half-maximal inhibitory concentration: > 50000 nM
Compound 4: only a limit was reported; the forecaster's own chance of this, stated with the estimate: 40%; middle value at least 2.0-fold (0.30 log units) away from the limit.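

In this assay, replacing 3-bromophenyl with 2,6-diethylphenyl on the aromatic nitrogen gives an at least 2.6-fold higher number from compound 3 to compound 4 (0.42 log units; beyond the scatter). Going by these compounds alone, this is the first readable step at this position, so the group held there can move the read-out beyond the scatter, with the change going towards weaker inhibition. Compound 4 gives only a limit, so the full size of the step stays unknown, and compound 3 remains the only compound with an actual number: the limit of > 50000 nM in this assay, at which 3 of the 4 values shown sit.

The compounds shown leave open whether the step follows the loss of the bromine or the arrival of the two ethyl groups. They also leave open how a phenyl ring carrying an amine or a carboxylic acid would read at this nitrogen, and whether any such group could give a lower number than compound 3.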